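The source may hold more compounds than are shown below. What is called first, only, known or untested is meant among the compounds shown, and "the series" means these compounds.

Compound 1 `N#C[Se]c1ccc(NC(=O)Oc2ccc(F)cc2)cc1` is the point of departure. In a functional assay on PC-3 cells (Homo sapiens) for cytotoxicity, read by MTT assay, with a stated time of 72 h (on this read-out lower numbers stand for stronger inhibition of growth and higher numbers for weaker inhibition of growth), compound 1 gives 11800 nM, the lowest of the three numbers, yet its gaps to compound 2 `CCCOC(=O)Nc1ccc([Se]C#N)cc1`, which gives 21100 nM, and to compound 3 `CC(C)COC(=O)Nc1ccc([Se]C#N)cc1`, which gives 21600 nM, both lie within the scatter, so no ranking among them is established. Within the data shown here, the only measured step, a 1.0-fold higher number from compound 2 to compound 3 (0.01 log units; within the scatter), changes a chain, not a ring, and so bears only loosely on the move to compound 4 `Cc1ccc(OC(=O)Nc2ccc([Se]C#N)cc2)cc1`, which shows (methyl in place of fluoro on an aromatic carbon). With nothing pointing to a change, a step of no more than the scatter is expected, in either direction, so that compound 4 is estimated at 12000 nM, between 5000 nM and 30000 nM, that is a 1.0-fold higher number from compound 1 to compound 4 (0.01 log units; within the scatter).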

Compound 4, concentration for 50% growth inhibition: 7600 nM
For compound 4 the middle estimate is 1.6-fold (0.20 log units) above the measured one, and the stated range covers the measured number.
By their numbers in this assay, from the lowest: compounds 4, 1, 2 and 3 (each within the scatter of the next, the first and the last beyond it).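

In this assay, putting methyl in place of fluoro on an aromatic carbon, para to a large group, gives a 1.6-fold lower number from compound 1 to compound 4 (0.19 log units; within the scatter) and so shows no clear effect of this exchange. Among these compounds, this is the first step measured on the ring rather than on a chain, and here these two groups cannot be told apart by growth inhibition. No other measurement is available to interpret this result. On these data alone, whether an amine, a carboxylic acid or a methoxy group on this carbon would give a number beyond the scatter remains open, as does the effect of plain hydrogen there.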